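The source may report more compounds than this note shows. Statements on the series, on what has been measured and on what is new or still open speak of the compounds shown alone.

Measured compounds in an ADME assay on microsomes from liver (Homo sapiens) for metabolic stability, read by LC-MS, using NADPH, tested at 5 uM; on this read-out higher numbers stand for a longer-lived compound and lower numbers for a shorter-lived compound:
compound 1, `Cc1cc(-c2ccccc2)n(/C(N)=N/S(=O)(=O)c2cc(C)c(Cl)cc2SCc2cccc3ccccc23)n1`, gives 0.256 h
compound 2, `Cc1cc(-c2ccccc2)n(/C(N)=N/S(=O)(=O)c2cc(C)c(Cl)cc2SCc2ccc(C(F)(F)F)cc2)n1`, gives 0.241 h
compound 3, `Cc1cc(S(=O)(=O)/N=C(\N)n2nccc2-c2ccccc2)c(SCc2ccc(C(F)(F)F)cc2)cc1Cl`, gives 0.176 h

Compound 1 and compound 2 share one core; compound 3 and the unmeasured compound 4, `Cc1cc(S(=O)(=O)/N=C(\N)n2nccc2-c2ccccc2)c(SCc2cccc3ccccc23)cc1Cl`, share another. The two cores differ in one place: hydrogen in place of methyl on an aromatic carbon. The step across this core change was a 1.4-fold lower number from compound 2 to compound 3 (0.14 log units; within the scatter).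

Going by the values given here, on the first core the group on the sulfur-bound chain carbon was varied once: naphthalen-1-yl in place of 4-(trifluoromethyl)phenyl on a saturated chain carbon bound to a sulfur. That step was a 1.1-fold higher number from compound 2 to compound 1 (0.03 log units; within the scatter).

The same change is now made on the second core: naphthalen-1-yl in place of 4-(trifluoromethyl)phenyl on a saturated chain carbon bound to a sulfur. The place is described in identical words for both pairs, so this is the same change, not merely the same kind. Among the compounds with values here, only one earlier instance of it exists, and the expectation rests on that alone. From compound 3 to compound 4 the expected step is a 1.1-fold higher number from compound 3 to compound 4 (0.03 log units; within the scatter), set beside the measured 1.1-fold higher number from compound 2 to compound 1 (0.03 log units; within the scatter), which lay within the scatter. Compound 4 is accordingly estimated at 0.19 h in this assay, with a range from 0.12 h to 0.32 h.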

Compound 4, half-life: 0.268 h
Estimate against measurement, compound 4: 1.4-fold (0.15 log units) below; the range from low to high includes it.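

In this assay, naphthalen-1-yl in place of 4-(trifluoromethyl)phenyl on a saturated chain carbon bound to a sulfur gives a 1.5-fold higher number from compound 3 to compound 4 (0.18 log units; within the scatter), and this step agrees with the earlier one on the other core: the same change on two cores in this assay, a 1.1-fold higher number (0.03 log units; within the scatter) from compound 2 to compound 1 and a 1.5-fold higher number (0.18 log units; within the scatter) from compound 3 to compound 4, 1.4-fold (0.16 log units) apart, within the scatter of two such steps

Hydrogen in place of methyl on an aromatic carbon reads a 1.0-fold higher number from compound 1 to compound 4 (0.02 log units; within the scatter), and this change also agrees across the pair: the same change on two cores in this assay, a 1.4-fold lower number (0.14 log units; within the scatter) from compound 2 to compound 3 and a 1.0-fold higher number (0.02 log units; within the scatter) from compound 1 to compound 4, 1.4-fold (0.16 log units) apart, within the scatter of two such steps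

Each step lies within the scatter, so the four compounds are consistent with both changes carrying from one core to the other, but they do not show that either change alters half-life, and a transfer of steps this small, seen on a single pair of cores, is a weak test of additivity.

Open, going by these compounds, is how a cyclohexyl group, a pyridine ring or a longer chain on the sulfur would behave in this assay. Also open, on these data alone, is whether a step beyond the scatter would carry between these two cores as closely.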